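The compounds below may be only part of what the source reports. "The series", "measured", "known", "first", "only" and "open" are said of these compounds alone.

Working notes on the series.

Of the compounds shown here, three sharing one core have been measured. Compound 1 `COc1cc(Nc2ncnc3c(NC(=O)Nc4cccc(Oc5ccccc5)c4)cccc23)cc(OC)c1` gives 14000 nM in a functional assay on RT-112 cells (Homo sapiens) for antiproliferative activity, read by MTT assay, with a stated time of 72 h; on this read-out higher numbers stand for weaker inhibition of growth and lower numbers for stronger inhibition of growth. Compound 3 `COc1cc(Nc2ncnc3c(NC(=O)c4ccc(N5CCN(C)CC5)cc4)cccc23)cc(OC)c1` gives 14200 nM in the same assay; the two values lie within the scatter of each other, so no order between them is claimed. Compound 2 `COc1cc(Nc2ncnc3c(NC(=O)Nc4ccc(Cl)c(C(F)(F)F)c4)cccc23)cc(OC)c1` gives only a limit of the assay, > 20000 nM, and no number. On the numbers shown, compound 2 therefore stands at the weak end: the limit of > 20000 nM in this assay, at which 1 of the 3 values shown sits.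

The step to be followed goes from compound 2 to compound 4 `COc1cc(Nc2ncnc3c(NC(=O)c4cc(=O)c5ccccc5o4)cccc23)cc(OC)c1`. Compound 4 differs from compound 2 in this way: a group of 11 heavy atoms (9 carbon, 2 oxygen; one six-membered aromatic ring of carbon only, one six-membered aromatic ring with 1 hetero atom) in place of a group of 12 heavy atoms (7 carbon, 1 nitrogen, 3 fluorine, 1 chlorine; one six-membered aromatic ring of carbon only), on a carbonyl carbon. The urea of compound 2 is thereby traded for an amide-type carbonyl carrying a fused bicyclic group without a common name.

Going by the values given here, no step between measured compounds is available to calibrate this change, and none of the measured compounds gives a value that stands out as strong. Compound 3, the one measured amide in the series, sits at 14200 nM, which is the nearest point of reference for compound 4. The expectation for compound 4 is a value in the same weak region, estimated at 15000 nM with a range of 5000 nM to 40000 nM. The expected step, from compound 2 to compound 4, is an at least 1.3-fold lower number from compound 2 to compound 4 (0.12 log units; that floor lies within the scatter), with a real chance that this assay again reports only a limit.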

Compound 4, concentration for 50% growth inhibition: > 20000 nM
Compound 4 gave a limit, no number; the forecaster's own chance of this, stated with the estimate: 35%; at least 1.3-fold (0.12 log units) between middle value and limit.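

In this assay compound 4 gives > 20000 nM, a limit of the assay and not a number. Going by these compounds alone, compound 2 gives > 20000 nM, also a limit, so no step from compound 2 to compound 4 can be read. The compounds shown leave open which of compound 2 and compound 4 inhibits growth more strongly, and by how much.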